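The source may hold more compounds than are shown below. What is called first, only, known or untested is meant among the compounds shown, and "the series" means these compounds.

- Compound 1 `COc1cc(NC(C)CCCNC(=O)NNC(=O)Nc2ccc(Cl)cc2)c2ncccc2c1`: 48000 nM
- Compound 2 `COc1cc(NC(C)CCCNC(=O)NNC(=O)Nc2ccc(C(F)(F)F)cc2)c2ncccc2c1`: 12000 nM
- Compound 3 `COc1cc(NC(C)CCCNC(=O)NNC(=O)Nc2ccc(Br)cc2)c2ncccc2c1`: 17000 nM

These numbers come from a functional assay on SW-620 cells (Homo sapiens) for inhibition, read by MTT assay, with a stated time of 72 h; on this read-out lower numbers stand for stronger inhibition and higher numbers for weaker inhibition. Compound 3 cannot be told apart from compound 2, with a 1.4-fold higher number from compound 2 to compound 3 (0.15 log units; within the scatter), and it clearly improves on compound 1, with a 2.8-fold lower number from compound 1 to compound 3 (0.45 log units; beyond the scatter).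

Compound 4 `COc1cc(NC(C)CCCNC(=O)NNC(=O)Nc2cccc(F)c2)c2ncccc2c1` has 3-fluorophenyl in place of 4-bromophenyl on an amide-type nitrogen. The closest measured changes are swaps on the aromatic carbon, which gave that same modest step and a 4.0-fold lower number from compound 1 to compound 2 (0.60 log units; beyond the scatter). For the measured compounds named here, no measured compound carries 3-fluorophenyl, so the direction is uncertain. A modest rise is expected, leaning toward compound 1 at 48000 nM. The expected change is a 1.6-fold higher number from compound 3 to compound 4 (0.22 log units; within the scatter). For compound 4 the estimated value is 28000 nM, with an expected range from 10000 nM to 70000 nM.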

Compound 4, half-maximal inhibitory concentration: 9500 nM
Estimate against measurement, compound 4: 2.9-fold (0.47 log units) above, and the stated range ends above it.
By their numbers in this assay, from the lowest: compounds 4, 2 and 3 (each within the scatter of the next); then compound 1.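

In this assay, 3-fluorophenyl on the amide-type nitrogen gives a 5.1-fold lower number from compound 1 to compound 4 (0.70 log units; beyond the scatter), a step beyond the scatter, while a 1.8-fold lower number from compound 3 to compound 4 (0.25 log units; within the scatter) and a 1.3-fold lower number from compound 2 to compound 4 (0.10 log units; within the scatter) both stay within it. This position therefore tolerates a change in both the halogen and its place on the ring, and 3-fluorophenyl groups with 4-bromophenyl and 4-(trifluoromethyl)phenyl, leaving only 4-chlorophenyl apart. Nothing available explains this result.

The compounds shown cannot separate the fluoro group from its ring place, a question that 4-fluorophenyl or 3-chlorophenyl could address. On these data alone, whether a phenyl ring carrying an amine or a carboxylic acid would fit here also remains open.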